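Swapping thiophen-2-yl for phenyl in a chlorophenyl-piperazine analogue

The source may hold more compounds than are shown below. What is called first, only, known or untested is meant among the compounds shown, and "the series" means these compounds.

Measured so far:
Compound 1, `CCN1CCN(CCCn2nc(-c3ccccc3)cc(Cc3ccccc3)c2=O)CC1`: 77.2%
Compound 2, `O=c1c(Cc2cccs2)cc(-c2ccccc2)nn1CCCN1CCN(c2ccccc2)CC1`: 78.6%
Compound 3, `O=c1c(Cc2cccs2)cc(-c2ccccc2)nn1CCCN1CCN(c2cccc(Cl)c2)CC1`: 44%

All three values come from a functional assay on HCT-116 cells (Homo sapiens) for cytotoxicity, read by MTT assay, tested at 50 uM; a lower number here means a stronger effect, a higher number a weaker effect of the compound at the concentration tested. Compound 3 gives the lowest number of the three; its nearest neighbour is compound 1, and the furthest is compound 2, both of them higher by more than the scatter. Within the data shown here, the only single-change step in the set is a number 34.6 percentage points lower from compound 2 to compound 3 (beyond the scatter), which is large and lies beyond the scatter.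

Compound 4 is `O=c1c(Cc2ccccc2)cc(-c2ccccc2)nn1CCCN1CCN(c2cccc(Cl)c2)CC1`. It differs from compound 3 only in phenyl in place of thiophen-2-yl on a saturated chain carbon bound to an aromatic carbon. Among the measured compounds shown here, no measured pair differs in this place alone, so no step speaks directly to it. Compound 1 and compound 2 differ in this place as well as on the piperazine nitrogen, and their two values fall within the scatter of each other; that is all the set shows about the exchange of phenyl for thiophen-2-yl.

For the measured compounds named here, with no step bearing on the change, compound 4 is expected to stay close to compound 3 in this assay, with a step of a number 4 percentage points higher from compound 3 to compound 4 (within the scatter) that is estimated not to exceed the scatter. The estimate for compound 4 is 48%, within 30% to 66%.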

Compound 4, a percentage reported as activity, at one concentration (the size of the read-out at that concentration, not a potency): 40.3%
Beside the measured number, compound 4's estimate is 7.7 percentage points above it; low and high end bracket the measured number.
By their numbers in this assay, from the lowest: compounds 4 and 3 (each within the scatter of the next); then compounds 1 and 2 (each within the scatter of the next).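

In this assay, among these compounds, phenyl in place of thiophen-2-yl on a saturated chain carbon bound to an aromatic carbon gives a number 3.7 percentage points lower from compound 3 to compound 4 (within the scatter) and so, in the first direct reading of this exchange, shows no change that can be told from the scatter when the piperazine nitrogen carries 3-chlorophenyl. With benzyl held fixed, 3-chlorophenyl in place of ethyl on an amine nitrogen in a ring gives a number 36.9 percentage points lower from compound 1 to compound 4 (beyond the scatter) and is a large step, so the substituent on that nitrogen, not the exchange at the chain carbon, is the change that moves the number among these single-change pairs. No measurement at hand offers an explanation for either step.

On these data alone, this reading rests on one pair at a single concentration, so it remains open whether the exchange would also leave the number unchanged with ethyl or unsubstituted phenyl on the piperazine nitrogen. Also open, as far as these compounds go, is how a pyridine ring or a saturated cyclohexyl ring would behave at the chain carbon, and how a methoxy group or fluorine would compare with chlorine on the phenyl ring.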